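Cyclohexylmethyl Analogue in a Bile Acid Receptor Series

The source may report more compounds than this note shows. Statements on the series, on what has been measured and on what is new or still open speak of the compounds shown alone.

The series shares the core seen in compound 1 `CC(C)c1onc(-c2c(Cl)cccc2Cl)c1COc1ccc(-c2nc3ccc(C(=O)O)cc3n2CC(C)(C)C)cc1`, which in an assay on isolated protein for agonist activity at Bile acid receptor (Homo sapiens), read by TR-FRET (on this read-out higher numbers stand for an effect only at larger amounts of compound and lower numbers for an effect already at smaller amounts), gives 24.8 nM. Compound 2 `CC(C)c1onc(-c2c(Cl)cccc2Cl)c1COc1ccc(-c2nc3ccc(C(=O)O)cc3n2C2CCCC2)cc1` has no result in this assay, recorded as "not determined" (no result reported). Compound 3 `CC(=O)C1CCC(Cn2c(-c3ccc(OCc4c(-c5c(Cl)cccc5Cl)noc4C(C)C)cc3)nc3ccc(C(=O)O)cc32)CC1` likewise stands without a number: in this assay compound 3 is reported as "not determined" (no result reported), so its position relative to compound 1 cannot be stated. Compound 4 `CC(C)c1onc(-c2c(Cl)cccc2Cl)c1COc1ccc(-c2nc3ccc(C(=O)O)cc3n2CC2CCCCC2)cc1` is reached from compound 3 by the change (hydrogen in place of acetyl on a saturated ring carbon). Within the data shown here, with no value for compound 3, no step can be computed and no direction beyond the scatter can be claimed. Because compound 1 gives 24.8 nM, compound 4 is expected to lie in the same region, estimated at 25 nM with a range of 8 nM to 80 nM.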

Compound 4, half-maximal effective concentration: 19.9 nM
The estimate for compound 4 lay 1.3-fold (0.10 log units) above the measured number, and the stated range covers the measured number.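

In this assay, among these compounds, the exchange of tert-butyl for cyclohexyl on the saturated chain carbon bound to an aromatic nitrogen comes to a 1.2-fold lower number from compound 1 to compound 4 (0.10 log units; within the scatter), the first step that can be read at this position. The position thus holds either group with no difference beyond the scatter. Nothing at hand bears on why the two groups read alike.

Among the compounds shown here, no step to compound 2 or compound 3 can be read. The compounds shown leave open how an amine or a carboxylic acid on the cyclohexyl ring, or a longer chain in place of the methyl link, would read.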